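From Bromo to Iodo: Tolerated Concentration in Liver Cells

The source may hold more compounds than are shown below. What is called first, only, known or untested is meant among the compounds shown, and "the series" means these compounds.

Compound 1 `Cc1ccccc1CNCc1cc(=O)c2c(O)c(O)ccc2o1`: 52200 nM
Compound 2 `O=c1cc(CNCc2ccc(Br)cc2)oc2ccc(O)c(O)c12`: > 100000 nM

In an ADME assay on Huh-7 cells (Homo sapiens) for cytotoxicity (a lower number here means that less compound is tolerated, a higher number that more compound is tolerated), compound 1 gives 52200 nM. For compound 2 the assay reports only a limit, > 100000 nM, so compound 2 sits at the limit of > 100000 nM in this assay, at which 1 of the 2 values shown sits. Among the compounds with values here, the single measured step, an at least 1.9-fold higher number from compound 1 to compound 2 (0.28 log units; that floor lies within the scatter), concerns a different part of the molecule and reaches only a floor within the scatter. Compound 3 `O=c1cc(CNCc2ccc(I)cc2)oc2ccc(O)c(O)c12` differs from compound 2 by iodo in place of bromo on an aromatic carbon. Within the data shown here, no measured step addresses this halogen swap. The expected step is a step that the limit leaves unreadable from compound 2 to compound 3, none beyond the scatter. Compound 3 is estimated at 150000 nM, between 60000 nM and 400000 nM.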

Compound 3, half-maximal cytotoxic concentration: 41700 nM
Estimate against measurement, compound 3: 3.6-fold (0.56 log units) above; the measured number lies below the stated range.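

Within the data shown here, the swap on this aromatic carbon, para to a large group, is the first change here that reads beyond the scatter in this assay: iodo in place of bromo gives an at least 2.3-fold lower number from compound 2 to compound 3 (0.37 log units; beyond the scatter). Compound 2 stands at a limit and not at a number: the limit of > 100000 nM in this assay, at which 1 of the 3 values shown sits. The iodo compound does not separate from the 2-methylphenyl compound, with a 1.3-fold lower number from compound 1 to compound 3 (0.10 log units; within the scatter).

Going by these compounds, how far apart compound 2 and compound 3 truly lie stays open. So does where a chloro or a methoxy group on the same aromatic carbon would fall.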